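Para group on the aryl ring: chloro after methoxy

The source may hold more compounds than are shown below. What is called first, only, known or untested is meant among the compounds shown, and "the series" means these compounds.

Among the compounds with values here, in a functional assay on HeLa cells (Homo sapiens) for antiproliferative activity, read by MTT assay, with a stated time of 48 h, in the presence of a further agent that is not named here (a lower number here means a stronger inhibitor of growth, a higher number a weaker inhibitor of growth), compound 3 `COc1ccc(-c2nn(-c3ccccc3)cc2C(=O)NOCc2ccccc2F)cc1` gives 2900 nM, the highest of the three numbers so far. Nearest is compound 2 `COc1ccc(-c2nn(-c3ccccc3)cc2C(=O)NOCc2ccccc2)cc1`, which gives 2640 nM; the two are within the scatter, as a 1.1-fold higher number from compound 2 to compound 3 (0.04 log units; within the scatter) shows. Furthest is compound 1 `Cc1ccc(-c2nn(-c3ccccc3)cc2C(=O)NOCc2ccccc2F)cc1`, which gives 1180 nM; here a 2.5-fold higher number from compound 1 to compound 3 (0.39 log units; beyond the scatter) lies beyond the scatter.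

Compound 4 `O=C(NOCc1ccccc1F)c1cn(-c2ccccc2)nc1-c1ccc(Cl)cc1` differs from compound 3 in one place: chloro in place of methoxy on an aromatic carbon. Within the data shown here, no measured pair carries a chloro on this ring, so the only step that bears on the change is the methyl-to-methoxy exchange, a 2.5-fold higher number from compound 1 to compound 3 (0.39 log units; beyond the scatter); the fluoro exchange on the other ring, a 1.1-fold higher number from compound 2 to compound 3 (0.04 log units; within the scatter), stayed within the scatter. Among the measured compounds shown here, of the two changes seen, only the one at the para position moved the number beyond the scatter, and loss of the methoxy is therefore expected to move compound 4 to a lower number than compound 3, by an amount of the order of that step, though chloro itself has no precedent here and the range is kept wide. Compound 4 is expected to give 1500 nM, between 600 nM and 4000 nM, which means a 1.9-fold lower number from compound 3 to compound 4 (0.29 log units; within the scatter) is expected.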

Compound 4, concentration for 50% growth inhibition: 4170 nM
Beside the measured number, compound 4's estimate is 2.8-fold (0.44 log units) below it, outside the stated range (above it).
By their numbers in this assay, from the lowest: compound 1; then compounds 2, 3 and 4 (each within the scatter of the next).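

Chloro in place of methoxy on the aromatic carbon para to a large group gives, in this assay, a 1.4-fold higher number from compound 3 to compound 4 (0.16 log units; within the scatter) and so does not separate the 4-chlorophenyl compound from the 4-methoxyphenyl compound; taking away the methoxy is not enough in itself to bring the number down. Against methyl the same chloro gives a 3.5-fold higher number from compound 1 to compound 4 (0.55 log units; beyond the scatter) and this sits with a 2.5-fold higher number from compound 1 to compound 3 (0.39 log units; beyond the scatter) as a second step beyond the scatter, so that among compound 1, compound 3 and compound 4 only the methyl compound stands apart, with the lowest number of the three, while chloro and methoxy group together. Nothing measured here gives a reason for this grouping.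

The compounds shown leave open whether the separation belongs to methyl alone or extends to other alkyl groups such as ethyl, and how an amine, a hydroxyl or a carboxylic acid at this position would read. On these data alone, the fluoro exchange on the other ring is also read only with methoxy in place, so whether it stays as small with methyl or chloro remains open.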